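From formyl to 2-(ethoxycarbonyl)ethenyl on compound 2

This account rests on a few compounds, and the source may have more. Where it says the series, first, only, none or still open, it means among the compounds named here.

Compound 1 `C=C[C@@](C)(/C=C/c1ccc(OS(=O)(=O)c2ccc(C)cc2)cc1)CCC=C(C)C` gives only a limit of > 43400 nM in a functional assay on SEM cells (Homo sapiens) for cytotoxicity, with a stated time of 72 h (on this read-out higher numbers stand for an effect only at larger amounts of compound and lower numbers for an effect already at smaller amounts), and no number. Among the compounds with values here, compound 2 `COc1ccc(/C=C/[C@@](C)(/C=C/c2ccc(O)c(C=O)c2)CCC=C(C)C)cc1` gives 4550 nM in this assay and holds the only actual number so far. Within the data shown here, compound 3 `CCOC(=O)/C=C/c1cc(/C=C/[C@](C)(/C=C/c2ccc(OC)cc2)CCC=C(C)C)ccc1O` carries 2-(ethoxycarbonyl)ethenyl in place of formyl on an aromatic carbon, ortho to a hydroxy group 2-(ethoxycarbonyl)ethenyl in place of formyl on an aromatic carbon as its one change. Among the measured compounds shown here, no measured pair shows what such a change does. The step of a 1.3-fold higher number from compound 2 to compound 3 (0.12 log units; within the scatter) is expected to lean slightly toward higher numbers and to stay within the usual scatter. In this assay compound 3 is estimated at 6000 nM with an expected range from 2000 nM to 18000 nM for this value.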

Compound 3, half-maximal effective concentration: > 36600 nM
Compound 3 was reported as a limit; the forecaster's own chance of this, stated with the estimate: 10%; middle value at least 6.1-fold (0.78 log units) from the limit.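

On an aromatic carbon ortho to a hydroxy group, 2-(ethoxycarbonyl)ethenyl in place of formyl is not a silent change: in this assay it brings an at least 8.0-fold higher number from compound 2 to compound 3 (0.90 log units; beyond the scatter) and leaves no measurable value. For compound 3 the value > 36600 nM is a limit, not a number, so the step has only a floor: the limit of > 36600 nM in this assay, at which 1 of the 3 values shown sits.

As far as these compounds go, the true size of the step stays open. So does which part of the new group goes with it: a plain ethenyl or a carboxylic acid in place of the ethyl ester would help separate these.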